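A few compounds are considered here, and "the series" means these few. Any claim that something is new, unique, unknown or untested is made for them only; others in the source may bear on it.

Measured so far in a physicochemical assay for solubility, read by LC-MS, in phosphate buffer, measured as kinetic solubility, with a stated time of 24 h, at 25 degrees C, at pH 7.4; a higher number here means a more soluble compound, a lower number a less soluble compound: compound 1 `Nc1nccc(-c2cc(OCc3ccccc3)c3c(N)n[nH]c3c2)n1` gives 85000 nM; compound 2 `Nc1nccc(-c2cc(OC3COC3)c3c(N)n[nH]c3c2)n1` gives 383000 nM; compound 3 `Nc1cc(-c2ccc3c(N)n[nH]c3c2)ncn1` gives 5000 nM.

Compound 2 holds the highest of these three numbers, with compound 1 nearest and compound 3 furthest off. Compound 4 `COc1cc(-c2ccnc(N)n2)cc2[nH]nc(N)c12` differs from compound 2 by methyl in place of oxetan-3-yl on an oxygen on an aromatic ring. Among the measured compounds shown here, only one measured step touches the same oxygen: a 4.5-fold higher number from compound 1 to compound 2 (0.65 log units; beyond the scatter), a modest change. For the measured compounds named here, no step from oxetan-3-yl to methyl has been measured, so that single step is only a loose guide, and a small shift at most is foreseen here, more likely downward than upward. On that basis compound 4 is expected to show a 1.9-fold lower number from compound 2 to compound 4 (0.28 log units; within the scatter). In this assay compound 4 is estimated at 200000 nM, with a range from 80000 nM to 450000 nM.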

Compound 4, solubility: > 100000 nM
Compound 4 gave a limit, no number (the forecaster's own chance of this, stated with the estimate: 5%); the middle value does not contradict the limit.
By their numbers in this assay, from the lowest: compound 3; then compound 1; then compound 2.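

In this assay compound 4 gives > 100000 nM as a limit of the assay and not a number. The step between compound 2 and compound 4 therefore cannot be read. The change from benzyl to methyl on this oxygen gives an at least 1.1-fold higher number from compound 1 to compound 4 (0.07 log units; that floor lies within the scatter) and so shows only that a methyl, with no ring, is enough to reach the limit, without separating the two compounds beyond the scatter.

Going by these compounds, how far compound 4 truly sits from compound 2 stays open. So does what an amine or a carboxylic acid on this oxygen would give.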